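The source may report more compounds than this note shows. Statements on the series, on what has been measured and on what is new or still open speak of the compounds shown alone.

In a functional assay on Bel-7402 cells (Homo sapiens) for inhibition, read by MTT assay, with a stated time of 24 h, tested at 10 ug/mL (a higher number here means more inhibition of growth at the concentration tested, a lower number less inhibition of growth), compound 1 `O=C(CCCCC(S)CCS)NO` gives 28.2%, compound 2 `O=C(CCCCC1CCSS1)Nc1cccc2ccccc12` gives 6.27%, and compound 3 `O=C(CCCCC(S)CCS)Nc1ccc(Cl)cc1` gives 1.16%. Compound 3 thus stands within the scatter of compound 2 and, beyond the scatter, under compound 1. Compound 4 `O=C(CCCCC(S)CCS)Nc1ccc([N+](=O)[O-])cc1` differs from compound 3 in one place: nitro in place of chloro on an aromatic carbon. This puts nitro in place of chloro on an aromatic carbon, para to a large group. Among the measured compounds shown here, no measured pair shows this change, and no step beyond the scatter is expected in this assay. The estimated step is a number 2.8 percentage points higher from compound 3 to compound 4 (within the scatter). For compound 4 the expected value is 4%, with an estimated range of 0% to 13%.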

Compound 4, percent growth inhibition at one concentration: 14.4%
Compound 4: middle estimate off by 10.4 percentage points, on the low side; measured number outside the range, above it.
By their numbers in this assay, from the lowest: compounds 3, 2 and 4 (each within the scatter of the next, the first and the last beyond it); then compound 1.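

In this assay, nitro in place of chloro on an aromatic carbon, para to a large group, gives a number 13.2 percentage points higher from compound 3 to compound 4 (beyond the scatter). Among the compounds shown here, this pair is the first to show that the group at this place can shift growth inhibition beyond the scatter, although the step is modest. Nothing measured here explains the shift.

On these data alone, whether an amine or a carboxylic acid on the same aromatic carbon would raise or lower the number remains open. A single pair also cannot show whether this step would recur on another core.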